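Swapping 4-Ethylphenyl for Phenethyl on a Sulfur

A few compounds are considered here, and "the series" means these few. Any claim that something is new, unique, unknown or untested is made for them only; others in the source may bear on it.

Among the compounds with values here, in a functional assay on A-375 cells (Homo sapiens) for inhibition, read by CCK-8 assay, with a stated time of 72 h, tested at 2 uM (a lower number here means less inhibition of growth, a higher number more inhibition of growth at the concentration tested), compound 1 `CCc1ccc(SCc2ccc(/C=C/C(=O)Nc3ccccc3N)cc2)cc1` gives 5.27%, the lower of the two numbers measured so far. Within the data shown here, the only other measured compound, compound 2 `Nc1ccccc1NC(=O)c1ccc(CSc2cccc(F)c2)cc1`, gives 37.7%, a gap beyond the usual scatter. Compound 3 `Nc1ccccc1NC(=O)/C=C/c1ccc(CSCCc2ccccc2)cc1` keeps the same atoms as compound 1 but joins them differently, with phenethyl in place of 4-ethylphenyl on a sulfur. Among the measured compounds shown here, no measured pair shows what this change does, so any forecast remains loose. Compound 1 stands low at 5.27%, which leaves more room for a rise than a fall, but a small upward move that stays within the scatter is the most that can be expected in this assay. The expected size of the step is a number 8.7 percentage points higher from compound 1 to compound 3 (within the scatter). Compound 3 is estimated at 14%, with an expected range of 2% to 38%.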

Compound 3, percent growth inhibition at one concentration: 41.9%
Compound 3: middle estimate off by 27.9 percentage points, on the low side, outside the stated range (above it).
By their numbers in this assay, from the lowest: compound 1; then compounds 2 and 3 (each within the scatter of the next).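

In this assay, phenethyl in place of 4-ethylphenyl on a sulfur gives a number 36.6 percentage points higher from compound 1 to compound 3 (beyond the scatter) in growth inhibition. Within the data shown here, this is the first pair among the measured compounds that differs in one place, and it shows that this position responds strongly to how the group on the sulfur is joined, even though the heavy atoms, the aromatic ring and the absence of hydrogen-bond donors and acceptors all stay the same. No available information bears on why this change has so large an effect.

From the compounds shown here alone, whether a longer chain between the sulfur and the phenyl ring would add to or reverse this step remains open. So does the effect of an amine or a carboxylic acid on the phenethyl ring.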